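Aryl versus benzyl on the core nitrogen

The source may hold more compounds than are shown below. What is called first, only, known or untested is meant among the compounds shown, and "the series" means these compounds.

Compound 1, `Cc1ccc(Nc2nc(Cl)nc3c2ncn3Cc2ccc(C(=O)Nc3ccccc3N)cc2)cc1`: 82%
Compound 2, `Nc1ccccc1NC(=O)c1ccc(Cn2cnc3c(Nc4ccccc4)nc(Cl)nc32)cc1`: 74.8%
Compound 3, `Nc1ccccc1NC(=O)c1ccc(Cn2cnc3c(NCc4ccccc4)nc(Cl)nc32)cc1`: 62.8%

Three compounds sharing one core were tested in a functional assay on HepG2 cells (Homo sapiens) for antiproliferative activity, read by CCK-8 assay, with a stated time of 72 h, tested at 8 uM; a higher number here means a stronger effect of the compound at the concentration tested, a lower number a weaker effect. Compound 3 stands lowest of the three in this assay; its nearest neighbour is compound 2, and the gap between them is beyond the scatter, as is the larger gap to compound 1.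

Compound 4, `Nc1ccccc1NC(=O)c1ccc(Cn2cnc3c(Nc4ccc(-c5ccccn5)cc4)nc(Cl)nc32)cc1`, has not yet been measured. It differs from compound 3 in one place: 4-(pyridin-2-yl)phenyl in place of benzyl on a nitrogen on an aromatic ring.

Going by the values given here, two measured steps bear on this change. Replacing phenyl with benzyl on that nitrogen gave a number 12 percentage points lower from compound 2 to compound 3 (beyond the scatter), and replacing 4-methylphenyl with benzyl gave a number 19.2 percentage points lower from compound 1 to compound 3 (beyond the scatter). Both steps moved the number downward when a benzyl entered, so a return to a phenyl-type group directly on the nitrogen, as in compound 4, is expected to move it back upward by a modest amount. Among the compounds with values here, the added pyridin-2-yl on that phenyl has no measured counterpart, so the size beyond that is uncertain.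

Compound 4 is therefore estimated to give 78% in this assay, within a range from 64% to 90%, which means an expected step of a number 15.2 percentage points higher from compound 3 to compound 4 (beyond the scatter).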

Compound 4, a percentage reported as inhibition, at one concentration (the size of the read-out at that concentration, not a potency): 41.2%
For compound 4 the middle estimate is 36.8 percentage points above the measured one; measured number below the stated range.
By their numbers in this assay, from the lowest: compound 4; then compound 3; then compounds 2 and 1 (each within the scatter of the next).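

In this assay, going by these compounds alone, an aryl group directly on the nitrogen does not by itself keep the number high: among the earlier compounds, phenyl and 4-methylphenyl both stood above benzyl, yet 4-(pyridin-2-yl)phenyl in place of benzyl gives a number 21.6 percentage points lower from compound 3 to compound 4 (beyond the scatter) rather than a rise. Within the data shown here, what is attached to that phenyl ring therefore matters far more than the earlier compounds suggested, since hydrogen and methyl there lay within the scatter of each other. Pyridin-2-yl in their place gives a number 33.6 percentage points lower from compound 2 to compound 4 (beyond the scatter) and a number 40.8 percentage points lower from compound 1 to compound 4 (beyond the scatter) and so marks the first large change seen at this position, with compound 4 now lowest of the four.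

Still open, from the compounds shown here alone, is whether the fall follows the second ring as such or its ring nitrogen, which a plain phenyl in place of pyridin-2-yl would help separate, and how smaller groups such as an amine or a methoxy on the same ring would compare with methyl and pyridin-2-yl. No measurement at hand offers a reason for the drop.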